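From compound 1 to a formyl-bearing analogue

The source may hold more compounds than are shown below. What is called first, only, known or untested is meant among the compounds shown, and "the series" means these compounds.

Among the compounds with values here, compound 1 `Cc1ccc(-c2cncc(Cl)c2N2CCC3(CCNC3=O)CC2)s1` gives 650 nM in a functional assay on MV4-11 cells (Homo sapiens) for inhibition, read by resazurin assay, with a stated time of 72 h (a lower number here means a stronger inhibitor of growth, a higher number a weaker inhibitor of growth), the lowest of the three numbers measured so far. Compound 2 `O=C1NCCC12CCN(c1c(Cl)cncc1-c1ccc(-c3ccccc3)s1)CC2`, with phenyl in place of methyl on an aromatic carbon, gives 960 nM in this assay, a step of a 1.5-fold higher number from compound 1 to compound 2 (0.17 log units; within the scatter). Compound 3 `O=C1NCCC12CCN(c1c(Cl)cncc1-c1ccc(CN3CCCCC3)s1)CC2`, with piperidin-1-yl on a saturated chain carbon bound to an aromatic carbon, gives 4010 nM in this assay; the step is a 6.2-fold higher number from compound 1 to compound 3 (0.79 log units; beyond the scatter), and from the phenyl analogue it is a 4.2-fold higher number from compound 2 to compound 3 (0.62 log units; beyond the scatter). Compound 4 `O=Cc1cc(-c2cncc(Cl)c2N2CCC3(CCNC3=O)CC2)cs1` is not yet measured. It differs from compound 1 by 5-formylthiophen-3-yl in place of 5-methylthiophen-2-yl on an aromatic carbon. Within the data shown here, none of the measured steps moves the point at which the five-membered aromatic ring is joined to the core, and none introduces a formyl group, so they bear on this change only loosely: a 1.5-fold higher number from compound 1 to compound 2 (0.17 log units; within the scatter) shows that a larger group at this aromatic carbon can be carried without a change beyond the scatter, while a 6.2-fold higher number from compound 1 to compound 3 (0.79 log units; beyond the scatter) shows that other appendages can give a modest loss. Compound 4 is therefore expected to give a modest step upward in this assay, namely a 2.3-fold higher number from compound 1 to compound 4 (0.36 log units; beyond the scatter). The estimate for compound 4 in this assay is 1500 nM, within a range from 500 nM to 5000 nM.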

Compound 4, concentration for 50% growth inhibition: 730 nM
Beside the measured number, compound 4's estimate is 2.1-fold (0.31 log units) above it; the range from low to high includes it.
By their numbers in this assay, from the lowest: compounds 1, 4 and 2 (each within the scatter of the next); then compound 3.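

Exchanging 5-methylthiophen-2-yl for 5-formylthiophen-3-yl on this aromatic carbon, ortho to a large group, gives in this assay a step of a 1.1-fold higher number from compound 1 to compound 4 (0.05 log units; within the scatter), so the two compounds cannot be told apart here. The earlier compounds shown here kept the same attachment of the five-membered aromatic ring and carried no formyl group; compound 4 shows that this position can take both differences at once without a change beyond the scatter. No measurement is at hand that would explain this result.

Since both differences arrive together, their separate contributions remain unresolved, and a 5-methylthiophen-3-yl or a 5-formylthiophen-2-yl group would be needed to divide them. On these data alone, it also remains open how this assay would read with a carboxylic acid or a hydroxymethyl group in place of the formyl group.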